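The source may hold more compounds than are shown below. What is called first, only, known or untested is meant among the compounds shown, and "the series" means these compounds.

Series in a functional assay on A549 cells (Homo sapiens) for antiproliferative activity, read by MTT assay, with a stated time of 48 h; a higher number here means a weaker inhibitor, a lower number a stronger inhibitor:
- compound 1 `COc1ccc(Nc2ccc3c(c2)C(O)(Cc2ccccc2)C(=O)N3)cc1`: > 30000 nM, a limit of the assay and not a number
- compound 2 `Cc1ccc(Nc2ccc3c(c2)C(O)(Cc2ccccc2)C(=O)N3)cc1`: 4100 nM
- compound 3 `CCCCCCC1(O)C(=O)Nc2ccc(Nc3ccc(F)cc3)cc21`: 12000 nM

Of the two true numbers, compound 2 gives 4100 nM and compound 3 gives the higher 12000 nM, a gap beyond the scatter. The next compound, compound 4 `O=C1Nc2ccc(Nc3ccc(F)cc3)cc2C1(O)Cc1ccccc1`, keeps the rest of compound 3 and carries phenyl in place of pentyl on a saturated chain carbon bound to a saturated ring carbon. This turns hexyl to benzyl, the group also carried by compound 1 and compound 2.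

For the measured compounds named here, no measured step changes this group. Going by the values given here, the only measured step, an at least 7.3-fold lower number from compound 1 to compound 2 (0.86 log units; beyond the scatter), is methyl in place of methoxy on an aromatic carbon, and one end of it is a limit: the limit of > 30000 nM in this assay, at which 1 of the 3 values shown sits. It bears only indirectly, showing that the benzyl compounds can differ widely in this assay through a change elsewhere.

A small move towards a lower number is therefore expected, probably not beyond the scatter, with the estimated step being a 1.5-fold lower number from compound 3 to compound 4 (0.18 log units; within the scatter). For compound 4 the estimate is 8000 nM, with an expected range of 2500 nM to 25000 nM.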

Compound 4, half-maximal inhibitory concentration: 3000 nM
The estimate for compound 4 lay 2.7-fold (0.43 log units) above the measured number; low and high end bracket the measured number.
By their numbers in this assay, from the lowest: compounds 4 and 2 (each within the scatter of the next); then compound 3. At a limit, above all of these: compound 1.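

For the compounds shown here, with the rest of compound 3 kept, hexyl to benzyl gives a 4.0-fold lower number from compound 3 to compound 4 (0.60 log units; beyond the scatter), the first measured evidence that this position itself moves the number, through phenyl in place of pentyl on a saturated chain carbon bound to a saturated ring carbon. With benzyl kept, fluoro in place of methyl gives a 1.4-fold lower number from compound 2 to compound 4 (0.14 log units; within the scatter), so this pair does not separate the two aromatic substituents. Fluoro in place of methoxy gives an at least 10-fold lower number from compound 1 to compound 4 (1.00 log units; beyond the scatter), a bound and not a number, since compound 1 stands at a limit of the assay: the limit of > 30000 nM in this assay, at which 1 of the 4 values shown sits.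

Whether the aromatic ring itself accounts for the step from hexyl to benzyl remains open, and a cyclohexylmethyl group at the same place would address this. On these data alone, how a phenethyl group or a chain ending in an amine would read at this position is also open.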